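Hydroxy for nitro on the aryl group of a xanthine core

This account rests on a few compounds, and the source may have more. Where it says the series, first, only, none or still open, it means among the compounds named here.

Measured compounds:
compound 1 `Cn1c(=O)c2nc(-c3ccccc3[N+](=O)[O-])[nH]c2n(C)c1=O` — 80 nM
compound 2 `Cn1c(=O)c2nc(-c3cccc(O)c3)[nH]c2n(C)c1=O` — 6 nM

Two compounds share the same core and differ only in the group carried on their phenyl ring. In an assay for binding affinity to adenosine receptor A1 (Bos taurus) (a higher number here means a weaker inhibitor, a lower number a stronger inhibitor), compound 1 gives 80 nM, and compound 2 gives 6 nM. Of the two numbers, that of compound 1 is the higher one, and the gap to compound 2 lies beyond the usual scatter, so compound 1 is the weaker binder of the pair.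

Compound 3 `Cn1c(=O)c2nc(-c3ccccc3O)[nH]c2n(C)c1=O` has not yet been measured in this assay. It is derived from compound 1 by a single change: hydroxy in place of nitro on an aromatic carbon. The new compound thus carries the same kind of group as compound 2, but on a different carbon of the phenyl ring, next to the core.

Compound 2 shows that a hydroxy on this ring can go with a low number, given 6 nM. Whether the same holds when the hydroxy sits ortho to the large core is not known from the data. A step downward from compound 1 is expected, probably of moderate size, and the estimate for the change from compound 1 to compound 3 is a 3.2-fold lower number from compound 1 to compound 3 (0.51 log units; beyond the scatter). For compound 3 the expected value is 25 nM, with a range from 5 nM to 120 nM.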

Compound 3, half-maximal inhibitory concentration: 10 nM
Beside the measured number, compound 3's estimate is 2.5-fold (0.40 log units) above it; the range from low to high includes it.
By their numbers in this assay, from the lowest: compounds 2 and 3 (each within the scatter of the next); then compound 1.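

In this assay hydroxy in place of nitro on an aromatic carbon ortho to a large group gives an 8.0-fold lower number from compound 1 to compound 3 (0.90 log units; beyond the scatter) and so shows that this carbon, too, can carry a hydroxy and reach a low number. Compound 3 gives 10 nM and compound 2 gives 6 nM and these two values lie within the usual scatter of each other, so the two carbons that carry the hydroxy in this pair cannot be told apart by their numbers. The data hold no independent measurement that would explain the step from nitro to hydroxy.

The compounds shown leave open whether the lower number belongs to hydroxy in particular, since an amine, a methoxy group or a carboxylic acid on the same carbon could give a lower, similar or higher number. Also open, on these data alone, is how a hydroxy would fare on any other carbon of the phenyl ring, and whether a second hydroxy or a fluorine added to compound 3 would move its number at all.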